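A few compounds are considered here, and "the series" means these few. Any claim that something is new, unique, unknown or untested is made for them only; others in the source may bear on it.

Measured in a functional assay on HL-60 cells (Homo sapiens) for cytotoxicity, read by luminescence and CellTiter-Glo, with a stated time of 3 days; on this read-out lower numbers stand for stronger inhibition and higher numbers for weaker inhibition:
- Compound 1 `COc1ccc(O)c(C(=O)Nc2ccc(C#N)cc2)c1`: > 10000 nM (a limit of the assay)
- Compound 2 `N#Cc1ccc(NC(=O)c2cc(Br)c3cccnc3c2O)cc1`: 330 nM
- Compound 3 `O=C(Nc1cc(C(F)(F)F)cc(C(F)(F)F)c1)c1cc(Br)c(F)cc1O`: 250 nM

Compound 1 stands at the limit of > 10000 nM in this assay, at which 1 of the 3 values shown sits. On these data alone, that entry is a limit and not a number, so the true position of compound 1 remains open.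

Compound 4 `N#Cc1ccc(NC(=O)c2cc(C(F)(F)F)ccc2O)cc1` has not yet been measured. It differs from compound 1 in one place, with trifluoromethyl in place of methoxy on an aromatic carbon, para to a hydroxy group (trifluoromethyl in place of methoxy on an aromatic carbon).

Going by the values given here, no matched step between measured compounds is available to size this change. Among the compounds with values here, the only guide is that compound 2 gives 330 nM and compound 3 gives 250 nM, two values within the scatter of each other, which show that measurable inhibition occurs in this small set.

In this assay, the expected step, an at least 6.6-fold lower number from compound 1 to compound 4 (0.82 log units; beyond the scatter), runs toward stronger inhibition and is large enough to leave the limit. Compound 4 is estimated at 1500 nM, with an expected range of 300 nM to 8000 nM.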

Compound 4, half-maximal inhibitory concentration: 3120 nM
For compound 4 the middle estimate is 2.1-fold (0.32 log units) below the measured one; the measured number falls inside the stated range.
By their numbers in this assay, from the lowest: compounds 3 and 2 (each within the scatter of the next); then compound 4. At a limit, above all of these: compound 1.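

In this assay, going by these compounds alone, the exchange of methoxy for trifluoromethyl on an aromatic carbon, para to a hydroxy group, gives an at least 3.2-fold lower number from compound 1 to compound 4 (0.50 log units; beyond the scatter) and so shows that this one position alone can move the read-out, which the earlier compounds, with no matched pair among them, could not show. Compound 1 stands at > 10000 nM and this entry is a limit of the assay, not a number. The step is therefore a minimum, and its true size cannot be read: the limit of > 10000 nM in this assay, at which 1 of the 4 values shown sits.

On these data alone, it remains open how an amine or a carboxylic acid would behave at this position, since only methoxy and trifluoromethyl are compared there. As far as these compounds go, it also remains open whether the same exchange would give a step of similar size on the cores of compound 2 or compound 3.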